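Swapping Methoxy for Ethyl: What to Expect

The compounds below may be only part of what the source reports. "The series", "measured", "known", "first", "only" and "open" are said of these compounds alone.

Compound 1 `COc1ccc(SCc2ccc(/C=C/C(=O)Nc3ccccc3N)cc2)cc1OC`: 65.5%
Compound 2 `Nc1ccccc1NC(=O)/C=C/c1ccc(CSc2ccc(Cl)cc2)cc1`: 55.3%
Compound 3 `COc1ccc(SCc2ccc(C(=O)Nc3ccccc3N)cc2)cc1`: 45.7%

All three compounds were tested in a functional assay on A549 cells (Homo sapiens) for inhibition, read by CCK-8 assay, with a stated time of 72 h, tested at 2 uM; on this read-out higher numbers stand for more inhibition of growth at the one concentration tested and lower numbers for less inhibition of growth. Compound 3 gives 45.7%, which lies within the scatter of compound 2 and clearly short of compound 1.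

The next compound is compound 4 `CCc1ccc(SCc2ccc(C(=O)Nc3ccccc3N)cc2)cc1`, which has ethyl in place of methoxy on an aromatic carbon. Among the compounds with values here, only one measured step bears on this change: a number 10.2 percentage points lower from compound 1 to compound 2 (beyond the scatter). That modest step put 4-chlorophenyl in place of 3,4-dimethoxyphenyl on a sulfur, so it also removed methoxy groups. Within the data shown here, it is only a loose guide, as the core of compound 1 differs from that of compound 3, and no measured pair swaps methoxy for ethyl directly. A small drop is therefore expected in this assay, and no change beyond the scatter.

The expected size of the change is a number 3.7 percentage points lower from compound 3 to compound 4 (within the scatter). Compound 4 is estimated at 42%, within an expected range of 30% to 54%.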

Compound 4, percent growth inhibition at one concentration: 53.6%
The estimate for compound 4 lay 11.6 percentage points below the measured number; measured number inside the range.
By their numbers in this assay, from the lowest: compounds 3, 4 and 2 (each within the scatter of the next); then compound 1.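

Ethyl in place of methoxy on an aromatic carbon, para to a large group, gives a number 7.9 percentage points higher from compound 3 to compound 4 (within the scatter) in this assay. Within the data shown here, this is the first direct reading of this swap on a single shared core: 4-ethylphenyl can stand in for 4-methoxyphenyl, with a hydrogen-bond acceptor leaving, and the number does not move beyond the scatter. No measurement at hand offers a reason for this outcome.

The compounds shown leave open how an amine, a carboxylic acid or a chain longer than ethyl would read at this same place. They also leave open whether the same swap of methoxy for ethyl would read alike on the core of compound 1.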